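The source may report more compounds than this note shows. Statements on the series, on what has been measured and on what is new or still open speak of the compounds shown alone.

The series rests on an arylpiperazine-propanone scaffold examined in an ADME assay on Vero cells (Chlorocebus sabaeus) for cytotoxicity, read by resazurin assay, with a stated time of 72 h; on this read-out higher numbers stand for weaker inhibition and lower numbers for stronger inhibition. Compound 1, `Cc1ccc(C(=O)CCN2CCN(c3ccc(F)cc3)CC2)cc1`, gives 55400 nM in this assay. Compound 2, `Cc1ccc(C(=O)CCN2CCN(c3ccc(C(F)(F)F)cc3)CC2)cc1`, gives 140000 nM. Compound 3, `O=C(CCN1CCN(c2ccc(F)cc2)CC1)c1ccc(F)c(F)c1`, gives 385000 nM, the highest of the three numbers. Compound 4, `O=C(CCN1CCN(c2ccc(C(F)(F)F)cc2)CC1)c1ccc(F)c(F)c1`, has not yet been measured in this assay.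

Two changes connect these compounds. The first, (trifluoromethyl in place of fluoro on an aromatic carbon), produced a 2.5-fold higher number from compound 1 to compound 2 (0.40 log units; beyond the scatter). The second, (3,4-difluorophenyl in place of 4-methylphenyl on a carbonyl carbon), produced a 6.9-fold higher number from compound 1 to compound 3 (0.84 log units; beyond the scatter); this is how the core of compound 3 differs from the core of compound 1.

The change from compound 3 to compound 4 is trifluoromethyl in place of fluoro on an aromatic carbon, and its place reads the same, word for word, as the place of the change from compound 1 to compound 2, so it is the same change applied to a different core. It occurs twice among the compounds shown, once measured and once not. Among the compounds with values here, with only one measured instance, whether the step carries over to the core of compound 3 cannot be checked against any further pair.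

Within the data shown here, the expectation for compound 4 therefore rests on compound 1 and compound 2, whose step a 2.5-fold higher number from compound 1 to compound 2 (0.40 log units; beyond the scatter) is the sole measured instance of this change. Compound 4 is expected to show a 2.5-fold higher number from compound 3 to compound 4 (0.39 log units; beyond the scatter) in this assay. Compound 4 is estimated at 950000 nM, with a range from 400000 nM to 2200000 nM.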

Compound 4, half-maximal inhibitory concentration: 14000 nM
For compound 4 the middle estimate is 68-fold (1.83 log units) above the measured one; measured number outside the range, below it.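

On the core of compound 3, trifluoromethyl in place of fluoro on the aromatic carbon gave a 28-fold lower number from compound 3 to compound 4 (1.44 log units; beyond the scatter) in this assay, so the step seen on the core of compound 1 did not carry over in either direction or size: the same change on two cores in this assay, a 2.5-fold higher number (0.40 log units; beyond the scatter) from compound 1 to compound 2 and a 28-fold lower number (1.44 log units; beyond the scatter) from compound 3 to compound 4, 69-fold (1.84 log units) apart, beyond the scatter of two such steps. The other change, 3,4-difluorophenyl in place of 4-methylphenyl on the carbonyl carbon, also reverses, giving a 10-fold lower number from compound 2 to compound 4 (1.00 log units; beyond the scatter) where the trifluoromethyl group is present: the same change on two cores in this assay, a 6.9-fold higher number (0.84 log units; beyond the scatter) from compound 1 to compound 3 and a 10-fold lower number (1.00 log units; beyond the scatter) from compound 2 to compound 4, 69-fold (1.84 log units) apart, beyond the scatter of two such steps. Both comparisons rest on the same four compounds, so together they show that the two changes do not combine independently here, but they do not show which core is the exception, why the reversal occurs, or whether it would hold on any other core.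

As far as these compounds go, it remains open whether the reversal belongs to trifluoromethyl itself or would also appear with a chloro or nitrile group on the same aromatic carbon. It is equally unclear whether a 4-methoxyphenyl group on the carbonyl carbon would follow the pattern of the 4-methylphenyl core or that of the 3,4-difluorophenyl core.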